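This account rests on a few compounds, and the source may have more. Where it says the series, first, only, none or still open, it means among the compounds named here.

In an ADME assay on microsomes (Mus musculus) for metabolic stability, with a stated time of 1 h, tested at 1 uM (on this read-out lower numbers stand for a less stable compound and higher numbers for a more stable compound), compound 2 (`C[C@@H]1CN([C@H](C)CO)C(=O)c2cccc(NC(=O)c3ccncc3)c2O[C@@H]1CN(C)Cc1ccc(Oc2ccccc2)cc1`) gives < 1%, a limit of the assay and not a number. Compound 1 (`C[C@H](CO)N1C[C@H](C)[C@H](CN(C)Cc2ccc(Oc3ccccc3)cc2)Oc2c(NC(=O)c3ccncc3)cccc2C1=O`) gives < 1%, also a limit. Compound 3 (`C[C@H]1CN([C@@H](C)CO)C(=O)c2cccc(NC(=O)c3ccncc3)c2O[C@@H]1CN(C)Cc1ccc(Oc2ccccc2)cc1`) arises from compound 2 through (the two compounds have the same atoms and bonds and differ only in configuration as drawn: 2 of 3 stereo elements differ; a stereocentre at a saturated ring carbon is drawn R in compound 2 and S in compound 3; a stereocentre at a saturated chain carbon is drawn R in compound 2 and S in compound 3). Going by the values given here, one measured step bears on this, given the fact that compounds 1 and 2 differ only in the configuration as drawn: a step that the two limits leave unreadable from compound 1 to compound 2. With compound 1 and compound 2 both at the limit of < 1% in this assay, at which 2 of the 2 values shown sit, no step beyond the scatter is expected in this assay. The expected change is a number no lower from compound 2 to compound 3 (the limit leaves the size open). Compound 3 is estimated at 1%, with an expected range of 0% to 6%.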

Compound 3, percent of the compound remaining: 77%
For compound 3 the middle estimate is 76 percentage points below the measured one, outside the stated range (above it).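

In this assay the result is a number at least 76 percentage points higher from compound 2 to compound 3 (beyond the scatter), and likewise a number at least 76 percentage points higher from compound 1 to compound 3 (beyond the scatter). The step from compound 1 to compound 2 cannot be read, so this is the first readable sign that configuration alone can carry a large change in this series: the fact that compounds 2 and 3 differ only in the configuration as drawn The same reading holds for the other pair: the fact that compounds 1 and 3 differ only in the configuration as drawn

Both steps change a saturated chain carbon together with a saturated ring carbon, so the compounds shown do not say which stereocentre carries the change. Going by these compounds, whether it would persist with a carboxylic acid in place of the hydroxyl also stays open.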